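Acetyl on the Sulfonamide Nitrogen: Compound 2 to Compound 3

This account rests on a few compounds, and the source may have more. Where it says the series, first, only, none or still open, it means among the compounds named here.

Compound 1 `COc1ccc(OC)c(-c2cc(-c3ccccc3)nn2-c2ccc(S(=O)(=O)NC(C)=O)cc2)c1`: 15300 nM
Compound 2 `NS(=O)(=O)c1ccc(-n2nc(-c3ccccc3)cc2-c2cc(O)ccc2O)cc1`: 88900 nM

In a functional assay on cells (Cancer cell lines, Homo sapiens) for cytotoxicity, read by sulforhodamine B assay, with a stated time of 48 h (a lower number here means a stronger inhibitor of growth, a higher number a weaker inhibitor of growth), compound 2 gives the highest of the two numbers; compound 1 gives the lower one, and the gap between them lies beyond the scatter. Compound 3 `CC(=O)NS(=O)(=O)c1ccc(-n2nc(-c3ccccc3)cc2-c2cc(O)ccc2O)cc1` differs from compound 2 by acetyl in place of hydrogen on a sulfonamide nitrogen. Compound 1 and compound 2 differ in more than one place, so the effect of the acetyl alone is not shown by any measured pair. A step of modest size is expected, from compound 2 to compound 3 a 1.5-fold lower number from compound 2 to compound 3 (0.17 log units; within the scatter), towards a lower number. For compound 3 the estimate is 60000 nM, within 20000 nM to 160000 nM.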

Compound 3, concentration for 50% growth inhibition: 93900 nM
For compound 3 the middle estimate is 1.6-fold (0.19 log units) below the measured one; the measured number falls inside the stated range.
By their numbers in this assay, from the lowest: compound 1; then compounds 2 and 3 (each within the scatter of the next).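

Measured in this assay the acetyl in place of hydrogen on the sulfonamide nitrogen gives a 1.1-fold higher number from compound 2 to compound 3 (0.02 log units; within the scatter) and so leaves this position without a readable effect in the presence of the 2,5-dihydroxyphenyl group. Among these compounds, with the acetyl kept, 2,5-dihydroxyphenyl in place of 2,5-dimethoxyphenyl on an aromatic carbon gives a 6.1-fold higher number from compound 1 to compound 3 (0.79 log units; beyond the scatter) and is the only change here that moves the number beyond the scatter. No measurement at hand explains either step.

From the compounds shown here alone, whether the acetyl would matter alongside the 2,5-dimethoxyphenyl group remains open. So does the effect of a methyl group or a longer acyl chain on the sulfonamide nitrogen.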